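The compounds below may be only part of what the source reports. "The series", "measured", "known", "first", "only" and "open" are said of these compounds alone.

The series is read in a functional assay on A549 cells (Homo sapiens) for antiproliferative activity, read by MTT assay, with a stated time of 48 h; a higher number here means a weaker inhibitor, a lower number a stronger inhibitor. Compound 1, `N#CC1=C(N)Oc2c(c3nc4ccccc4nc3c3ccccc23)C12C(=O)N(Cc1cnnn1-c1cccc(S(N)(=O)=O)c1)c1ccccc12`, gives in this assay 44200 nM, a weak result. Compound 2, `N#CC1=C(N)Oc2c(N)cc3nc4ccccc4nc3c2C12C(=O)N(Cc1cnnn1-c1ccc(Cl)cc1)c1ccccc12`, gives in this assay > 50000 nM, which is a limit of the assay and not a number; this is the case noted as the limit of > 50000 nM in this assay, at which 1 of the 2 values shown sits. Compound 2 thus stands at the weak end of what this assay can report, without a number of its own. Compound 3, `COc1ccc(OC)c(-n2nncc2CN2C(=O)C3(C(C#N)=C(N)Oc4c(N)cc5nc6ccccc6nc5c43)c3ccccc32)c1`, differs from compound 2 in one place: 2,5-dimethoxyphenyl in place of 4-chlorophenyl on an aromatic nitrogen. For the measured compounds named here, no measured step between compounds that differ in one place exists in this assay, so the size of this change can only be anticipated. The change is expected to stay within the scatter, with compound 3 remaining weak, so that the expected step is an at least 1.1-fold lower number from compound 2 to compound 3 (0.04 log units; that floor lies within the scatter). Compound 3 is estimated at 45000 nM in this assay, within a range from 15000 nM to 135000 nM.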

Compound 3, half-maximal inhibitory concentration: 28100 nM
For compound 3 the middle estimate is 1.6-fold (0.20 log units) above the measured one; the measured number falls inside the stated range.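

In this assay, the substituent on the aromatic nitrogen now has its first measured change: 2,5-dimethoxyphenyl in place of 4-chlorophenyl gives an at least 1.7-fold lower number from compound 2 to compound 3 (0.25 log units; that floor lies within the scatter). Compound 2 gives > 50000 nM, which is a limit of the assay and not a number, so this step is only a floor: the limit of > 50000 nM in this assay, at which 1 of the 3 values shown sits. The change therefore brings the series from the limit to a readable value, but this single pair shows no shift beyond the scatter and sets no trend for this position.

From the compounds shown here alone, the true size of the step remains open, as does the separate contribution of the 4-chlorophenyl loss and the two methoxy groups. Also open, going by these compounds, is how an aromatic ring bearing an amine or a carboxylic acid, or a simple alkyl chain, would read at this position.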